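The compounds below may be only part of what the source reports. "The series", "measured", "known", "first", "only" and "open" are said of these compounds alone.

Three compounds share one core and differ only in the aromatic group attached to a nitrogen on an aromatic ring. Compound 1 `FC(F)(F)c1ccc(CSc2nc(Nc3ccccc3C(F)(F)F)c3ccccc3n2)cc1` carries a 2-(trifluoromethyl)phenyl there; in a functional assay on MCF7 cells (Homo sapiens) for cytotoxicity, read by MTT assay, with a stated time of 72 h (a higher number here means a weaker inhibitor, a lower number a stronger inhibitor), compound 1 gives only a limit of the assay, > 50000 nM. Compound 2 `FC(F)(F)c1ccc(CSc2nc(Nc3cccc(C(F)(F)F)c3)c3ccccc3n2)cc1` carries a 3-(trifluoromethyl)phenyl, and in this assay compound 2 gives 15300 nM. Compound 3 `COc1ccc(Nc2nc(SCc3ccc(C(F)(F)F)cc3)nc3ccccc23)cc1` carries a 4-methoxyphenyl, and in this assay compound 3 gives 47200 nM, the highest of the two real numbers, with compound 2 nearest: a 3.1-fold higher number from compound 2 to compound 3 (0.49 log units; beyond the scatter). Against the limit of compound 1 the other two steps read an at least 3.2-fold lower number from compound 1 to compound 2 (0.51 log units; beyond the scatter) and an at least 1.0-fold lower number from compound 1 to compound 3 (0.02 log units; that floor lies within the scatter).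

Compound 4 `COc1cc(Nc2nc(SCc3ccc(C(F)(F)F)cc3)nc3ccccc23)cc(OC)c1` has not been measured. Its change from compound 3 is 3,5-dimethoxyphenyl in place of 4-methoxyphenyl on a nitrogen on an aromatic ring. Among the measured compounds shown here, no measured step exchanges one methoxyphenyl for another; the only precedents are exchanges of the whole aromatic group on that nitrogen, which moved this assay by modest amounts in both directions. A step of similar or smaller size is therefore the most that is expected, with no clear direction. Compound 4 is expected near 40000 nM, within 15000 nM to 150000 nM. That estimate means an expected step of a 1.2-fold lower number from compound 3 to compound 4 (0.07 log units; within the scatter).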

Compound 4, half-maximal inhibitory concentration: 6990 nM
Estimate against measurement, compound 4: 5.7-fold (0.76 log units) above, outside the stated range (below it).
By their numbers in this assay, from the lowest: compound 4; then compound 2; then compound 3. At a limit, above all of these: compound 1.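

In this assay, among the compounds shown here, exchanging 4-methoxyphenyl for 3,5-dimethoxyphenyl gives a 6.8-fold lower number from compound 3 to compound 4 (0.83 log units; beyond the scatter), the largest step so far between two real numbers, so changing the methoxy pattern on this aromatic group can matter more than the earlier exchange of the whole group between compound 2 and compound 3. The new group also improves on both trifluoromethyl-bearing groups, with a 2.2-fold lower number from compound 2 to compound 4 (0.34 log units; beyond the scatter) and an at least 7.1-fold lower number from compound 1 to compound 4 (0.85 log units; beyond the scatter), which makes compound 4 the strongest of the four. Compound 1 stands at a limit of the assay, so any step from it is only a floor: the limit of > 50000 nM in this assay, at which 1 of the 4 values shown sits.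

Still open, on these data alone, is whether the gain comes from having a second methoxy group or from where the methoxy groups sit, a question that 3-methoxyphenyl on that nitrogen would help settle. Also open, as far as these compounds go, is how 3,5-dimethylphenyl or 3,5-dihydroxyphenyl would compare.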